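Swapping the Carbonyl Side Group of Compound 3

This account rests on a few compounds, and the source may have more. Where it says the series, first, only, none or still open, it means among the compounds named here.

Measured in an ADME assay on L02 cells (Homo sapiens) for cytotoxicity, read by MTT assay; on this read-out lower numbers stand for stronger inhibition and higher numbers for weaker inhibition:
- Compound 1 `COc1ccc(/C=C/C(=O)c2ccc(OC)c3c2OC(C)(C)C=C3)cc1OCCCN(C)C`: 8600 nM
- Compound 2 `COc1ccc(/C=C/C(=O)c2ccc(OC)c3c2OC(C)(C)C=C3)cc1OC(=O)CCl`: > 10000 nM (a limit, not a number)
- Compound 3 `COc1cccc(C(=O)Oc2cc(/C=C/C(=O)c3ccc(OC)c4c3OC(C)(C)C=C4)ccc2OC)c1`: > 10000 nM (a limit, not a number)

Compound 3 gives only a limit, > 10000 nM. That value is the limit of > 10000 nM in this assay, at which 2 of the 3 values shown sit.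

The next compound, compound 4 `COc1ccc(/C=C/C(=O)Oc2cc(/C=C/C(=O)c3ccc(OC)c4c3OC(C)(C)C=C4)ccc2OC)cc1`, differs from compound 3 in one place: 2-(4-methoxyphenyl)ethenyl in place of 3-methoxyphenyl on a carbonyl carbon. In words, 2-(4-methoxyphenyl)ethenyl stands in place of 3-methoxyphenyl on a carbonyl carbon.

Going by the values given here, three measured steps bear on this change. The first two are an at least 1.1-fold higher number from compound 1 to compound 2 (0.06 log units; that floor lies within the scatter) and an at least 1.1-fold higher number from compound 1 to compound 3 (0.06 log units; that floor lies within the scatter), and neither floor goes beyond the scatter. The third swaps the group on this same carbonyl carbon, but it is a step that the two limits leave unreadable from compound 2 to compound 3. These steps give no sign of a large shift, so no step beyond the scatter is expected in this assay, and a further limit is the likely result. The expected change is a step that the limit leaves unreadable from compound 3 to compound 4. Compound 4 is estimated at 15000 nM, with an expected range of 7000 nM to 40000 nM.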

Compound 4, half-maximal inhibitory concentration: 18000 nM
The estimate for compound 4 lay 1.2-fold (0.08 log units) below the measured number, and the stated range covers the measured number.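

In this assay, the (2-(4-methoxyphenyl)ethenyl)carbonyl group gives compound 4 a readable number, whereas the chloromethyl and 3-methoxyphenyl groups on the same carbonyl carbon each give only a limit. Measured against the 3-(dimethylamino)propyl group on the same oxygen, this change produces a 2.1-fold higher number from compound 1 to compound 4 (0.32 log units; beyond the scatter), so the number moves modestly but measurably. The steps to compound 4 from compound 2 and compound 3 cannot be read, because both of those compounds sit at a limit: the limit of > 10000 nM in this assay, at which 2 of the 4 values shown sit.

Compound 4 differs from compound 3 in both the ethenyl link and the placing of the methoxy group, so the two changes remain tangled. A 2-(3-methoxyphenyl)ethenyl group on this carbonyl carbon would separate them, while an amine on the carbonyl side chain would test whether the 3-(dimethylamino)propyl result carries over to this linkage.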